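From Chloro to Methoxy: Expected Change in Enzyme Inhibition

The source may report more compounds than this note shows. Statements on the series, on what has been measured and on what is new or still open speak of the compounds shown alone.

Compound 1, `COc1ccc(C(=O)/C=C/c2cccnc2)cc1OC`, gives 3100 nM in an ADME assay on microsomes for inhibition of cytochrome P450 1A1 (Homo sapiens), read by fluorescence, with a stated time of 10 min; a higher number here means a weaker inhibitor, a lower number a stronger inhibitor.
Compound 2, `O=C(/C=C/c1ccc(F)c(F)c1)c1cccnc1`, gives 11800 nM in this assay.
Compound 3, `O=C(/C=C/c1cccnc1)c1cccc(Cl)c1`, gives 3400 nM in this assay.

Among these three numbers, compound 3 has the second highest. Its value sits within the usual scatter of that of compound 1, so the two cannot be told apart on this evidence. Compound 2 gives a clearly higher number than compound 3, a gap beyond the scatter, meaning compound 2 is the weaker inhibitor of the two.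

The next compound, compound 4, `COc1cccc(C(=O)/C=C/c2cccnc2)c1`, differs from compound 3 in a single place: methoxy in place of chloro on an aromatic carbon. Going by the values given here, no pair of measured compounds differs in exactly this way, so no measured step can be read off directly. What the data do show is that compound 1, which carries methoxy groups on the same ring, gives a value within the scatter of compound 3. On that basis compound 4 is expected to stay close to compound 3, with an estimated step of a 1.2-fold higher number from compound 3 to compound 4 (0.07 log units; within the scatter), not beyond the scatter in either direction. The estimate for compound 4 in this assay is 4000 nM, with a range from 1500 nM to 10000 nM.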

Compound 4, half-maximal inhibitory concentration: 3500 nM
For compound 4 the middle estimate is 1.1-fold (0.06 log units) above the measured one; the range from low to high includes it.
By their numbers in this assay, from the lowest: compounds 1, 3 and 4 (each within the scatter of the next); then compound 2.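

Exchanging chloro for methoxy on this aromatic carbon, meta to a large group, gives a 1.0-fold higher number from compound 3 to compound 4 (0.01 log units; within the scatter) in this assay, so at this place the two groups cannot be told apart in this assay, even though they differ in heavy atoms and in hydrogen-bond acceptors. The other new comparison concerns the number of methoxy groups on that ring: with hydrogen in place of one methoxy on an aromatic carbon, the result is a 1.1-fold higher number from compound 1 to compound 4 (0.05 log units; within the scatter), so that methoxy makes no difference that can be detected here. Nothing among the available data explains why either exchange makes so little difference.

Two similar results do not show that this position accepts any group, and an amine or a carboxylic acid on the same aromatic carbon would be a much sterner test of that idea. From the compounds shown here alone, it also remains open whether a compound with only hydrogen at this place would fall within the scatter of compound 3 and compound 4, or whether having some group here matters at all.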